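Aryl ether to aryl thioether on the shared core

The source may report more compounds than this note shows. Statements on the series, on what has been measured and on what is new or still open speak of the compounds shown alone.

Compound 1 `Nc1cc(N)c2nc(-c3ccccc3)c(Oc3ccc(Cl)c(Cl)c3)nc2c1` is the reference of the set. In a functional assay on A549 cells (Homo sapiens) for inhibition, read by sulforhodamine B assay, with a stated time of 48 h (on this read-out higher numbers stand for weaker inhibition of growth and lower numbers for stronger inhibition of growth), compound 1 gives 18200 nM. Compound 3 `CCOC(=O)[C@H](CCC(=O)O)NC(=O)c1ccc(Sc2nc3cc(N)cc(N)c3nc2-c2ccccc2)cc1` gives 20400 nM in this assay, a number that lies within the scatter of that of compound 1, so the two are not told apart. For compound 2 `CCOC(=O)[C@H](CCC(=O)O)NC(=O)c1ccc(CNc2nc3cc(N)cc(N)c3nc2-c2ccccc2)cc1` the result in this assay is only a limit, < 100000 nM. One of the three values is thus (the limit of < 100000 nM in this assay, at which 1 of the 3 values shown sits).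

Compound 4 `Nc1cc(N)c2nc(-c3ccccc3)c(Sc3ccc(F)cc3)nc2c1` differs from compound 1 by (4-fluorophenyl)sulfanyl in place of 3,4-dichlorophenoxy on an aromatic carbon. For the measured compounds named here, no measured pair covers this change; compound 3 shows that a sulfanyl-linked aryl group can sit close to compound 1, so only a small step is expected, if any beyond the scatter. Compound 4 is estimated at 25000 nM in this assay, with a range of 8000 nM to 80000 nM. This estimate implies a 1.4-fold higher number from compound 1 to compound 4 (0.14 log units; within the scatter) in this assay.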

Compound 4, concentration for 50% growth inhibition: 13500 nM
The estimate for compound 4 lay 1.9-fold (0.27 log units) above the measured number, within the range that was stated.
By their numbers in this assay, from the lowest: compounds 4, 1 and 3 (each within the scatter of the next).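

For the compounds shown here, at this aromatic carbon next to the ring nitrogen, the exchange gives a 1.3-fold lower number from compound 1 to compound 4 (0.13 log units; within the scatter) in this assay, the first direct pair at this position. The aryl group on the shared core can therefore carry either linking atom and either halogen pattern without a change that can be told apart from the scatter. No result shown gives a cause for this step.

The pair changes linking atom and ring halogens together, so neither can be read alone. Going by these compounds, how a piperidine or a longer alkyl chain on this carbon would read remains open.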